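Swapping an aromatic ring on two related cores

The source may report more compounds than this note shows. Statements on the series, on what has been measured and on what is new or still open speak of the compounds shown alone.

Four compounds share most of their skeleton and differ in the aromatic group carried on a five-membered ring with three nitrogen atoms, or in how the core atoms are joined. Compound 1 `C=C1C[C@]23C[C@@]1(O)CC[C@H]2c1ccc(O)c(C)c1[C@@H]3Cn1cc(-c2ccccn2)nn1` carries pyridin-2-yl. In a functional assay on HL-60 cells (Homo sapiens) for cytotoxicity, read by MTT assay, with a stated time of 4 days (on this read-out higher numbers stand for weaker inhibition and lower numbers for stronger inhibition), compound 1 reaches only the limit of the assay, > 20000 nM. Compound 2 `C=C1C[C@]23C[C@@]1(O)CC[C@H]2c1ccc(O)c(C)c1[C@@H]3Cn1cc(-c2ccc(C(F)(F)F)cc2)nn1` bears 4-(trifluoromethyl)phenyl instead, the change (4-(trifluoromethyl)phenyl in place of pyridin-2-yl on an aromatic carbon). In this assay compound 2 gives 8950 nM. That change brought an at least 2.2-fold lower number from compound 1 to compound 2 (0.34 log units; beyond the scatter), and the limit of > 20000 nM in this assay, at which 2 of the 3 values shown sit, bounds how large the step truly is. Compound 3 `Cc1c(O)ccc2c1[C@H](Cn1cc(-c3ccccn3)nn1)[C@@]13CC(=O)[C@@](C)(CC[C@@H]21)C3` holds the same pyridin-2-yl group on a core built from the same atoms joined differently; the difference between the two cores is not broken down here. In this assay compound 3 likewise sits at the limit, > 20000 nM. Compound 4 `Cc1c(O)ccc2c1[C@H](Cn1cc(-c3ccc(C(F)(F)F)cc3)nn1)[C@@]13CC(=O)[C@@](C)(CC[C@@H]21)C3` is not yet measured and differs from compound 3 by 4-(trifluoromethyl)phenyl in place of pyridin-2-yl on an aromatic carbon, the same change at a place described in identical words. Compound 4 is expected to show an at least 2.0-fold lower number from compound 3 to compound 4 (0.30 log units; that floor lies within the scatter), resting on an at least 2.2-fold lower number from compound 1 to compound 2 (0.34 log units; beyond the scatter). Compound 4 is therefore estimated at 10000 nM, between 4000 nM and 25000 nM.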

Compound 4, half-maximal inhibitory concentration: > 20000 nM
Compound 4 was reported as a limit; the forecaster's own chance of this, stated with the estimate: 35%; middle value at least 2.0-fold (0.30 log units) away from the limit.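

In this assay compound 4 gives > 20000 nM, which is a limit of the assay and not a number. Compound 3 also sits at a limit, so no step can be read between compound 3 and compound 4: the limit of > 20000 nM in this assay, at which 3 of the 4 values shown sit.

The compounds shown leave open whether 4-(trifluoromethyl)phenyl in place of pyridin-2-yl lowers the number at all on the core of compound 3.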